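Swapping a Sulfonyl Substituent: Expected Liver Clearance

The source may hold more compounds than are shown below. What is called first, only, known or untested is meant among the compounds shown, and "the series" means these compounds.

Compound 1 `Nc1cc(S(=O)(=O)c2ccc(F)cc2)cnc1C(=O)N1CC(O)(C(F)(F)F)C1`: 28.3 mL/min/kg
Compound 2 `CN(Cc1ccccc1)S(=O)(=O)c1cc(C(N)=O)c(NC(=O)c2ccn[nH]2)s1`: 1880 mL/min/kg

Both compounds were run in an ADME assay on microsomes from liver (Rattus norvegicus) for metabolic stability; on this read-out higher numbers stand for fast clearance and lower numbers for slow clearance. Compound 2 has the higher of the two numbers, and its gap to compound 1 lies well beyond the scatter. Compound 3 `NC(=O)c1cc(S(=O)(=O)c2ccc(F)cc2)sc1NC(=O)c1ccn[nH]1` differs from compound 2 by one change: 4-fluorophenyl in place of benzyl(methyl)amino on a sulfonyl sulfur. For the measured compounds named here, no measured pair shows this change, so the expectation rests on compound 1, which also carries a 4-fluorophenyl on its sulfonyl sulfur and gives 28.3 mL/min/kg. A downward step a 6.3-fold lower number from compound 2 to compound 3 (0.80 log units; beyond the scatter) beyond the scatter is expected. Compound 3 is estimated at 300 mL/min/kg, with a range from 60 mL/min/kg to 1500 mL/min/kg.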

Compound 3, clearance: 71.7 mL/min/kg
For compound 3 the middle estimate is 4.2-fold (0.62 log units) above the measured one, within the range that was stated.
By their numbers in this assay, from the lowest: compound 1; then compound 3; then compound 2.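

In this assay, putting 4-fluorophenyl in place of benzyl(methyl)amino on a sulfonyl sulfur gives a 26-fold lower number from compound 2 to compound 3 (1.42 log units; beyond the scatter) and so a large step. This shows that a single change at this place on an otherwise unchanged core can move the clearance read-out strongly, which compound 1 and compound 2, differing in many places, could not show. Nothing at hand explains the size of this step. Still open, on these data alone, is whether a plain phenyl, without the fluorine, gives a similar number, and whether a smaller amine such as dimethylamino or morpholine on the same sulfur stays close to compound 2.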